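Bromo to Methyl on the Benzyl Amide of Compound 3

A few compounds are considered here, and "the series" means these few. Any claim that something is new, unique, unknown or untested is made for them only; others in the source may bear on it.

Compound 1 `COc1ccc(CNC(=O)CN2C(=O)/C(=C/c3ccc(-c4ccc(Cl)cc4)o3)SC2=S)cc1` gives 44000 nM in a functional assay on REH cells (Homo sapiens) for cytotoxicity, read by MTT assay, with a stated time of 72 h; a higher number here means a weaker inhibitor, a lower number a stronger inhibitor.
Compound 2 `Cc1ccc(CNC(=O)CN2C(=O)/C(=C/c3ccc(-c4ccc(Cl)cc4)o3)SC2=S)cc1` gives 45000 nM.
Compound 3 `O=C(CN1C(=O)/C(=C/c2ccc(-c3ccc(Cl)cc3)o2)SC1=S)NCc1ccc(Br)cc1` gives 75000 nM.

Compound 3 carries the highest number of the three, yet the steps of a 1.7-fold higher number from compound 1 to compound 3 (0.23 log units; within the scatter) and a 1.7-fold higher number from compound 2 to compound 3 (0.22 log units; within the scatter) both sit within the scatter, so no real order among them can be claimed. Compound 4 `Cc1cccc(CNC(=O)CN2C(=O)/C(=C/c3ccc(-c4ccc(Cl)cc4)o3)SC2=S)c1` differs from compound 3 by 3-methylphenyl in place of 4-bromophenyl on a saturated chain carbon bound to an amide-type nitrogen. For the measured compounds named here, the step of a 1.7-fold higher number from compound 2 to compound 3 (0.22 log units; within the scatter) is the one measured exchange of bromo for methyl, and it stayed within the scatter; no measured pair addresses the 3-methylphenyl arrangement itself. The expectation is therefore a small step back toward the numbers of compounds 1 and 2, not beyond the scatter: a 1.5-fold lower number from compound 3 to compound 4 (0.18 log units; within the scatter). Compound 4 is estimated at 50000 nM, with a range from 25000 nM to 100000 nM.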

Compound 4, half-maximal inhibitory concentration: 53000 nM
Estimate against measurement, compound 4: 1.1-fold (0.03 log units) below; low and high end bracket the measured number.
By their numbers in this assay, from the lowest: compounds 1, 2, 4 and 3 (each within the scatter of the next).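

In this assay, the exchanges on a saturated chain carbon bound to an amide-type nitrogen give a 1.4-fold lower number from compound 3 to compound 4 (0.15 log units; within the scatter), a 1.2-fold higher number from compound 2 to compound 4 (0.07 log units; within the scatter) and a 1.2-fold higher number from compound 1 to compound 4 (0.08 log units; within the scatter), and all three lie within the scatter. The pair of 4-methylphenyl and 3-methylphenyl adds something new: moving the methyl on the ring, and not only exchanging the group, also gives no readable difference. Nothing available here offers an explanation for these small steps.

Still open, on these data alone, is whether a carboxylic acid or an amine on this ring, or a longer chain in place of the benzyl group, would give a step beyond the scatter.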